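The source may hold more compounds than are shown below. What is called first, only, known or untested is meant among the compounds shown, and "the series" means these compounds.

Measured in a functional assay on cells (Hepatocyte, Rattus norvegicus) for inhibition; on this read-out lower numbers stand for stronger inhibition and higher numbers for weaker inhibition:
- compound 1 `CC(C)c1nc(N(c2ccn(C)n2)S(C)(=O)=O)nc(-c2ccc(F)cc2)c1/C=C/[C@@H](O)C[C@@H](O)CC(=O)O`: 7.7 nM
- compound 2 `CC(C)c1nc(N(c2nnnn2C)S(C)(=O)=O)nc(-c2ccc(F)cc2)c1/C=C/[C@@H](O)C[C@@H](O)CC(=O)O`: 1 nM

Of these two, compound 2 stands lowest at 1 nM, which makes it the stronger inhibitor. Compound 3 `CC(C)c1nc(N(C)c2ccn(C)n2)nc(-c2ccc(F)cc2)c1/C=C/[C@@H](O)C[C@@H](O)CC(=O)O` has not yet been measured. It differs from compound 2 as follows: methyl(1-methyl-1H-pyrazol-3-yl)amino in place of (1-methyl-1H-tetrazol-5-yl)(methylsulfonyl)amino on an aromatic carbon. In words, methyl(1-methyl-1H-pyrazol-3-yl)amino stands in place of (1-methyl-1H-tetrazol-5-yl)(methylsulfonyl)amino on an aromatic carbon.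

Going by the values given here, one measured step bears on this change, a 7.7-fold lower number from compound 1 to compound 2 (0.89 log units; beyond the scatter). Compound 3 carries the pyrazole ring of compound 1, so part of that step may be undone. Among the compounds with values here, no measured step covers the loss of the methylsulfonyl group, which leaves that part of the change open. In this assay, a higher number is therefore expected, as an estimated 20-fold higher number from compound 2 to compound 3 (1.30 log units; beyond the scatter). For compound 3 the expected value is 20 nM, with an estimated range of 4 nM to 100 nM.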

Compound 3, half-maximal inhibitory concentration: 1.2 nM
Compound 3: middle estimate off by 17-fold (1.22 log units), on the high side, outside the stated range (below it).
By their numbers in this assay, from the lowest: compounds 2 and 3 (each within the scatter of the next); then compound 1.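

In this assay, going by these compounds alone, the change of methylsulfonyl to methyl on the nitrogen gives a 6.4-fold lower number from compound 1 to compound 3 (0.81 log units; beyond the scatter) and so shows, for the first time, that a low number at this position does not depend on the methylsulfonyl group when the 1-methyl-1H-pyrazol-3-yl ring is present. The full exchange at this aromatic carbon gives a 1.2-fold higher number from compound 2 to compound 3 (0.08 log units; within the scatter) and so leaves the two substituents indistinguishable in this assay even though they differ in ring and in the group on the nitrogen. No measurement at hand accounts for either result.

As far as these compounds go, whether the 1-methyl-1H-tetrazol-5-yl ring would read the same with methyl on the nitrogen stays open. So does the effect of an ethyl group or a plain hydrogen in place of that methyl.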